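Amine swap on the chalcone of compound 1

The compounds below may be only part of what the source reports. "The series", "measured", "known", "first", "only" and "open" are said of these compounds alone.

Measured so far in a functional assay on HL-60 cells (Homo sapiens) for antiproliferative activity, with a stated time of 72 h; on this read-out lower numbers stand for stronger inhibition and higher numbers for weaker inhibition:
- compound 1 `CCN(C)Cc1c(OC)cc(OC)c(C(=O)/C=C/c2ccccc2Cl)c1O`: 200 nM
- compound 2 `COc1cc(O)c2c(=O)cc(-c3ccccc3Cl)oc2c1CN1CCCCC1`: 48100 nM
- compound 3 `COc1cc(OC)c2c(=O)cc(-c3ccccc3Cl)oc2c1CN1CCCCC1`: 34500 nM

Compound 1 gives the lowest number of the three; compound 3 sits a long way above it and compound 2 further still, both gaps beyond the scatter. Within the data shown here, the only single-point step is a 1.4-fold lower number from compound 2 to compound 3 (0.14 log units; within the scatter), which concerns the oxygen substituent on the core of compounds 2 and 3 and says nothing about the amine.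

Compound 4 `COc1cc(OC)c(C(=O)/C=C/c2ccccc2Cl)c(O)c1CN1CCCCC1` is compound 1 with the change (piperidin-1-yl in place of ethyl(methyl)amino on a saturated chain carbon bound to an aromatic carbon). Among the measured compounds shown here, no measured pair isolates this change: compounds 2 and 3 carry the piperidine but also a different core, so the large gap from compound 1 to them cannot be assigned to the amine. On that basis the amine swap is expected to move this assay by a modest step at most, with the core of compound 1 retained, and a 2.0-fold higher number from compound 1 to compound 4 (0.30 log units; within the scatter) is the expected step. Compound 4 is estimated at 400 nM, between 100 nM and 3000 nM.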

Compound 4, half-maximal inhibitory concentration: 3600 nM
Compound 4: the middle estimate sits 9.0-fold (0.95 log units) below what was measured; the whole stated range lies below it.
By their numbers in this assay, from the lowest: compound 1; then compound 4; then compounds 3 and 2 (each within the scatter of the next).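

In this assay, among these compounds, the amine on the saturated chain carbon bound to an aromatic carbon is not a silent place on the core of compound 1: an 18-fold higher number from compound 1 to compound 4 (1.26 log units; beyond the scatter) is the first step that isolates this position, and it lies beyond the scatter. The change is (ethyl(methyl)amino)methyl to (piperidin-1-yl)methyl, so an amine without a ring gives way to one held in a six-membered non-aromatic ring, with the rest of the chalcone untouched. No measurement at hand accounts for the size of this step.

A single pair cannot separate the ring from the larger group, and pyrrolidin-1-yl or diethylamino at the same place would bear on that. From the compounds shown here alone, whether the amine matters as much on the core of compounds 2 and 3 stays open, since that would take ethyl(methyl)amino on that core.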